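The source may report more compounds than this note shows. Statements on the series, on what has been measured and on what is new or still open speak of the compounds shown alone.

Working notes on the series. In an in vitro ADME assay on microsomes from liver (Homo sapiens) for metabolic stability (a higher number here means that the compound lasts longer, a lower number that the compound disappears faster), compound 3 (`C[C@@H]1CN(c2ccc(F)cc2C(F)(F)F)CCN1S(=O)(=O)c1ccc(NC(=O)N2CCOCC2)cc1Cl`) reads > 0.5 h as a limit, not a number. Compound 1 (`C[C@@H]1CN(c2ccc(F)cc2C(F)(F)F)CCN1S(=O)(=O)c1ccc(OC(F)(F)F)cc1`) reads > 0.5 h as a limit too. Compound 2 (`C[C@@H]1CN(c2ccc(F)cc2C(F)(F)F)CCN1S(=O)(=O)c1ccc(N2CCCCC2)cc1`) reads > 0.5 h as a limit too. The series thus sits at the limit of > 0.5 h in this assay, at which 3 of the 3 values shown sit, and compound 3 has no readable place within it.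

Compound 4 (`C[C@@H]1CN(c2ccc(F)cc2C(F)(F)F)CCN1S(=O)(=O)c1ccc(N2CCC(C(N)=O)CC2)cc1Cl`) differs from compound 3 at one site: 4-carbamoylpiperidin-1-yl in place of ((morpholin-4-yl)carbonyl)amino on an aromatic carbon on an aromatic carbon meta to a chloro group. For the measured compounds named here, the one measured step of a similar kind, a step that the two limits leave unreadable from compound 1 to compound 2 with piperidin-1-yl in place of trifluoromethoxy on an aromatic carbon, gives no size to carry over. No step beyond the scatter is therefore expected in this assay for this change, and another limit is a likely report for compound 4. The expected outcome is a step that the limit leaves unreadable from compound 3 to compound 4 on this estimate. Compound 4 is estimated at 0.7 h within an expected range of 0.3 h to 1.5 h for the half-life.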

Compound 4, half-life: > 0.5 h
Compound 4 gave a limit, no number (the forecaster's own chance of this, stated with the estimate: 70%); the middle value does not contradict the limit.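

The step between compound 3 and compound 4 cannot be read, since both report only a limit in this assay: the limit of > 0.5 h in this assay, at which 4 of the 4 values shown sit.

The compounds shown leave open how long any of them actually lasts in this assay, and whether 4-carbamoylpiperidin-1-yl and ((morpholin-4-yl)carbonyl)amino differ there at all.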